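Methyl for hydrogen on two different five-membered rings

A few compounds are considered here, and "the series" means these few. Any claim that something is new, unique, unknown or untested is made for them only; others in the source may bear on it.

Of the compounds shown here, three with a shared core have been measured in an ADME assay on Vero cells (Chlorocebus sabaeus) for cytotoxicity; a lower number here means that less compound is tolerated, a higher number that more compound is tolerated. Compound 1 `O[C@@H]1Cc2ccccc2N[C@H](c2cccs2)C1` gives 986000 nM in this assay. Compound 2 `Cc1ccsc1[C@@H]1C[C@H](O)Cc2ccccc2N1` gives 616000 nM in this assay; it differs from compound 1 in one place, methyl in place of hydrogen on an aromatic carbon and the step of a 1.6-fold lower number from compound 1 to compound 2 (0.20 log units; within the scatter) is small. Compound 3 `O[C@@H]1Cc2cc(OC(F)(F)F)ccc2N[C@H](c2ccco2)C1` gives 166000 nM in this assay, the lowest of the three numbers and beyond the scatter from both others; how its core differs from the core of compound 1 is not broken down here.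

Compound 4 `Cc1ccc([C@@H]2C[C@H](O)Cc3cc(OC(F)(F)F)ccc3N2)o1` has not been measured. Going by the values given here, it differs from compound 3 in one place, methyl in place of hydrogen on an aromatic carbon and this is the same kind of change as the one from compound 1 to compound 2, though not the same: in compound 2 the methyl sits on a five-membered aromatic ring with one sulfur, next to the ring atom that bears a large group and two ring bonds from the ring sulfur, whereas in compound 4 it sits on a five-membered aromatic ring with one oxygen, next to the ring oxygen and two ring bonds from the ring atom that bears a large group. Among the compounds with values here, because the one measured example of this kind of change, a 1.6-fold lower number from compound 1 to compound 2 (0.20 log units; within the scatter), stayed within the scatter, the step from compound 3 to compound 4 in this assay is expected to be small as well, a 1.3-fold lower number from compound 3 to compound 4 (0.11 log units; within the scatter). In this assay compound 4 is therefore estimated at 130000 nM, with a likely range from 60000 nM to 300000 nM.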

Compound 4, half-maximal cytotoxic concentration: 82100 nM
Compound 4: middle estimate off by 1.6-fold (0.20 log units), on the high side, and the stated range covers the measured number.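

Going from furan-2-yl to 5-methylfuran-2-yl gives a 2.0-fold lower number from compound 3 to compound 4 (0.31 log units; beyond the scatter) in this assay, a modest step. Set beside the earlier methyl step, it shows that this change has so far had an effect of similar size on both cores, with no difference between the two steps that can be told from scatter: the same change on two cores in this assay, a 1.6-fold lower number (0.20 log units; within the scatter) from compound 1 to compound 2 and a 2.0-fold lower number (0.31 log units; beyond the scatter) from compound 3 to compound 4, 1.3-fold (0.10 log units) apart, within the scatter of two such steps

Going by these compounds alone, this does not show a general rule for the series, since only two pairs are available, only the newer step lies beyond the scatter, and the methyl sits on a different five-membered aromatic ring and in a different place in each pair, so the part played by the ring, the place and the rest of the core cannot be separated.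

The compounds shown leave open what a longer chain such as ethyl, an amine or a carboxylic acid would do in the place of this methyl on the five-membered aromatic ring with one oxygen. They also leave open whether the same methyl step would hold on the core of compound 1 with that ring, or on any third core.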